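Enantiomer step from compound 2 to compound 3

This account rests on a few compounds, and the source may have more. Where it says the series, first, only, none or still open, it means among the compounds named here.

compound 1 `Clc1ccc(N2CC[C@@H]3CN[C@@H]3C2)cn1` — 24 nM
compound 2 `Clc1cc(N2CC[C@H]3CN[C@H]3C2)cnc1Cl` — 12 nM

In a functional assay on HEK293 cells for agonist activity at Neuronal acetylcholine receptor; alpha4/beta2 (Homo sapiens), read by FLIPR (on this read-out higher numbers stand for an effect only at larger amounts of compound and lower numbers for an effect already at smaller amounts), compound 2 gives 12 nM; compound 1 gives 24 nM, and that gap lies within the scatter, so the two stand level. Compound 3 `Clc1cc(N2CC[C@@H]3CN[C@@H]3C2)cnc1Cl` is the mirror image of compound 2: the two compounds have the same atoms and bonds and differ only in configuration as drawn: 2 of 2 stereo elements differ (all stereocentres are inverted: mirror images); a stereocentre at a saturated ring carbon is drawn S in compound 2 and R in compound 3; a stereocentre at a saturated ring carbon is drawn R in compound 2 and S in compound 3. Among the compounds with values here, no measured pair shows what inverting both centres does on this read-out. The expected step is toward weaker activity, an 8.3-fold higher number from compound 2 to compound 3 (0.92 log units; beyond the scatter), with wide uncertainty, since mirror images may also stay level. Compound 3 is estimated at 100 nM, range 10 nM to 1500 nM.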

Compound 3, half-maximal effective concentration: 82 nM
Compound 3: the middle estimate sits 1.2-fold (0.09 log units) above what was measured; low and high end bracket the measured number.
By their numbers in this assay, from the lowest: compounds 2 and 1 (each within the scatter of the next); then compound 3.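

Configuration of the shared core matters in this assay: the mirror-image pair gives a 6.8-fold higher number from compound 2 to compound 3 (0.83 log units; beyond the scatter), the first read on inverting both centres. The step can be assigned to configuration alone because of one fact: the fact that compounds 2 and 3 differ only in the configuration as drawn

With chloro in place of hydrogen on an aromatic carbon, the series also gives a 3.4-fold higher number from compound 1 to compound 3 (0.53 log units; beyond the scatter), a single pair in one configuration as drawn. From the compounds shown here alone, whether that chloro step holds in the configuration of compound 2 remains open. Also open, going by these compounds, is how a nitrile or a methoxy group would stand in place of that chloro.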